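Compound 3 to compound 4: fluoro replaced by hydrogen

The source may hold more compounds than are shown below. What is called first, only, known or untested is meant among the compounds shown, and "the series" means these compounds.

Compound 3 (`O=C(/C=C/c1ccc(F)cc1)Nc1nnc(-c2ccc(Cl)cc2)s1`) gives 2.06 ug/mL in a functional assay on A549 cells (Homo sapiens) for antiproliferative activity, read by MTT assay, with a stated time of 48 h; on this read-out higher numbers stand for weaker inhibition and lower numbers for stronger inhibition. That is within the scatter of compound 2 (`O=C(/C=C/c1ccccc1)Nc1nnc(-c2ccc(Br)cc2)s1`) at 2.18 ug/mL and of compound 1 (`O=C(/C=C/c1ccc(C(F)(F)F)cc1)Nc1nnc(-c2ccc(Cl)cc2)s1`) at 3.09 ug/mL. Compound 4 (`O=C(/C=C/c1ccccc1)Nc1nnc(-c2ccc(Cl)cc2)s1`) has hydrogen in place of fluoro on an aromatic carbon, 4-fluorophenyl to phenyl: hydrogen in place of fluoro on an aromatic carbon. For the measured compounds named here, the one measured single-place step, a 1.5-fold lower number from compound 1 to compound 3 (0.18 log units; within the scatter), also changes this substituent and is small. Compound 2, which also carries the phenyl, gives 2.18 ug/mL. No shift beyond the scatter is therefore expected, in either direction, in this assay. The expected change is a 1.1-fold higher number from compound 3 to compound 4 (0.03 log units; within the scatter). For compound 4 the estimated value is 2.2 ug/mL, with an expected range of 1.2 ug/mL to 3.9 ug/mL.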

Compound 4, half-maximal inhibitory concentration: 2.02 ug/mL
The estimate for compound 4 lay 1.1-fold (0.04 log units) above the measured number, within the range that was stated.
By their numbers in this assay, from the lowest: compounds 4, 3, 2 and 1 (each within the scatter of the next).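

With hydrogen on this aromatic carbon, the series stays within the scatter whether it replaces fluoro, a 1.0-fold lower number from compound 3 to compound 4 (0.01 log units; within the scatter), or trifluoromethyl, a 1.5-fold lower number from compound 1 to compound 4 (0.18 log units; within the scatter), so a substituent at this carbon is not needed to hold the number in this range. For the compounds shown here, the first single-place step at the other aromatic ring, chloro in place of bromo, a 1.1-fold lower number from compound 2 to compound 4 (0.03 log units; within the scatter), also stays within the scatter. No measurement offers a reason for these results.

As far as these compounds go, whether an amine, a carboxylic acid or a methoxy group on this carbon would give a step beyond the scatter remains open.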